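The source may report more compounds than this note shows. Statements on the series, on what has been measured and on what is new or still open speak of the compounds shown alone.

Compound 1 `CNC(=O)c1cc(C(=O)NCCO)cn(Cc2ccccc2)c1=O`: 1.9
Compound 2 `CNC(=O)c1cc(C(=O)NC2CC2)cn(Cc2cccc3cc[nH]c23)c1=O`: 3.7

Of the compounds shown here, two have been measured in a physicochemical assay for lipophilicity, at pH 7.4; a lower number here means a more polar compound, a higher number a more lipophilic compound. In this assay compound 1 gives 1.9, and compound 2 gives 3.7. Compound 2 thus stands highest of the two numbers, and its nearest neighbour, compound 1, lies a good way lower, beyond the scatter. Among the measured compounds shown here, since compound 1 and compound 2 differ in more than one place, no single structural step between them can be read off; the two values show only that compound 2 is the more lipophilic of the pair.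

The unmeasured compound 3 `CNC(=O)c1cc(C(=O)NC2CC2)cn(CC2CCCCC2)c1=O` follows from compound 2 by one change: cyclohexyl in place of 1H-indol-7-yl on a saturated chain carbon bound to an aromatic nitrogen. For the measured compounds named here, no measured step of this kind is available, so the expected direction rests on the change itself. The step from compound 2 to compound 3 is expected to be a modest rise, a number 0.50 log units higher from compound 2 to compound 3 (beyond the scatter), likely beyond the scatter but not large. On that basis compound 3 is estimated to give about 4.2 in this assay, with a range from 3.6 to 4.8.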

Compound 3, distribution coefficient: 4
The estimate for compound 3 lay 0.20 log units above the measured number, and the stated range covers the measured number.
By their numbers in this assay, from the lowest: compound 1; then compounds 2 and 3 (each within the scatter of the next).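

Among the compounds shown here, this is the first step that can be read at a single place: on a saturated chain carbon bound to an aromatic nitrogen, putting cyclohexyl in place of 1H-indol-7-yl gives, in this assay, a number 0.30 log units higher from compound 2 to compound 3 (within the scatter). On paper the two groups are quite different, since 1H-indol-7-yl has 9 heavy atoms, two aromatic rings and 1 hydrogen-bond donor, while cyclohexyl has 6 heavy atoms, one non-aromatic ring and no donor, yet this pair cannot be told apart in this assay. No measurement is available that bears on why these two groups give such similar numbers.

Still open, going by these compounds, is how the number would respond at this place to a group of another kind, such as an amine, a carboxylic acid or a longer carbon chain in place of cyclohexyl. For the compounds shown here, compound 1 differs from compound 2 and compound 3 in more than one place, so no step to it can be read, and how its differing groups each contribute remains unknown.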